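The compounds below may be only part of what the source reports. "The series", "measured", "known", "first", "only" and "open" are said of these compounds alone.

Measured in a functional assay on MGC-803 cells (Homo sapiens) for antiproliferative activity, read by MTT assay, with a stated time of 72 h; a lower number here means a stronger inhibitor, a higher number a weaker inhibitor:
- compound 1 `Cc1ccc(-c2nc(CNc3ccc(C(=O)NO)cc3)n(-c3ccccc3)n2)cc1`: > 20000 nM, a limit
- compound 2 `COc1ccc(-c2nc(CNc3ccc(C(=O)NO)cc3)n(-c3ccccc3)n2)cc1`: > 20000 nM, a limit
- compound 3 `O=C(NO)c1ccc(NCc2nc(-c3cc4ccccc4s3)nn2-c2ccccc2)cc1`: 6110 nM

Within the data shown here, compound 3 holds the only actual number in the set. The other readings stop at the limit of > 20000 nM in this assay, at which 2 of the 3 values shown sit. Between those two compounds there is a step that the two limits leave unreadable from compound 1 to compound 2.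

The next change gives compound 4 `O=C(NO)c1ccc(NCc2nc(-c3ccccc3)nn2-c2ccccc2)cc1`: phenyl in place of 1-benzothiophen-2-yl on an aromatic carbon. The group that changes sits between two ring nitrogen atoms.

Among the measured compounds shown here, two measured steps touch that same place: an at least 3.2-fold lower number from compound 1 to compound 3 (0.51 log units; beyond the scatter), and an at least 3.2-fold lower number from compound 2 to compound 3 (0.51 log units; beyond the scatter). Both are beyond the scatter, but both rest on limits, so they fix only a minimum size. Like compounds 1 and 2, compound 4 has a single six-membered aromatic ring of carbon only at this place. A higher number in this assay is therefore expected, reversing those two steps at a comparable or larger size, and a reading at the limit is quite possible. The expected step is a 3.3-fold higher number from compound 3 to compound 4 (0.51 log units; beyond the scatter). For compound 4 the estimated value is 20000 nM, with an expected range of 8000 nM to 60000 nM.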

Compound 4, half-maximal inhibitory concentration: 17700 nM
Estimate against measurement, compound 4: 1.1-fold (0.05 log units) above; the measured number falls inside the stated range.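

Compound 4 puts an actual number on the unsubstituted phenyl at this place, so the gain from 1-benzothiophen-2-yl can now be sized rather than only bounded: in this assay the change gives a 2.9-fold higher number from compound 3 to compound 4 (0.46 log units; beyond the scatter). Hydrogen in place of the para-free substituents cannot be sized, as the remaining steps are floors set by limits, an at least 1.1-fold lower number from compound 2 to compound 4 (0.05 log units; that floor lies within the scatter) and an at least 1.1-fold lower number from compound 1 to compound 4 (0.05 log units; that floor lies within the scatter), so neither methoxy nor methyl on the phenyl can be given an effect. Compound 1 and compound 2 therefore remain unplaced relative to compound 4, and both are read only as limits: the limit of > 20000 nM in this assay, at which 2 of the 4 values shown sit.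

Open, on these data alone, is whether 2-naphthyl, with two rings and no sulfur, or thiophen-2-yl, with sulfur and one ring, would match compound 3. As far as these compounds go, an amine or a carboxylic acid on the phenyl of compound 4 is equally open.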